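The source may report more compounds than this note shows. Statements on the series, on what has been measured and on what is new or still open speak of the compounds shown alone.

Within the data shown here, compound 2, `COc1cc(/C=C/C(=O)c2cccc(NC(=O)c3cccs3)c2)ccc1O`, is the weaker of the two compounds measured so far: in a functional assay on HUVEC cells (Homo sapiens) for inhibition, tested at 5 ug/mL (a lower number here means a weaker effect, a higher number a stronger effect of the compound at the concentration tested), compound 2 gives 80%, the lowest of the two numbers, while compound 1, `COc1cc(/C=C/C(=O)c2cccc(NC(=O)c3c(Cl)cccc3Cl)c2)ccc1O`, gives 88%, and the step of a number 8 percentage points lower from compound 1 to compound 2 (within the scatter) lies within the scatter, so the two compounds cannot be ordered on these data. Compound 3, `COc1cc(/C=C/C(=O)c2cccc(NC(=O)c3cc(Cl)cc(Cl)c3)c2)ccc1O`, has not yet been measured. It differs from compound 2 in one place: 3,5-dichlorophenyl in place of thiophen-2-yl on a carbonyl carbon. Among the measured compounds shown here, only one measured step bears on this change, the exchange at the same carbonyl carbon of 2,6-dichlorophenyl for thiophen-2-yl, a number 8 percentage points lower from compound 1 to compound 2 (within the scatter), which was within the scatter. With compound 3 a 3,5-dichlorophenyl enters at that carbonyl carbon, a group of the same kind as the one whose removal made no difference beyond the scatter. The expectation for compound 3 in this assay is therefore a step of no more than the scatter, if anything slightly upward, estimated as a number 4 percentage points higher from compound 2 to compound 3 (within the scatter). Compound 3 is accordingly expected to give about 84% in this assay, with a range from 68% to 95%.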

Compound 3, a percentage reported as inhibition, at one concentration (the size of the read-out at that concentration, not a potency): 51%
The estimate for compound 3 lay 33 percentage points above the measured number, outside the stated range (below it).
By their numbers in this assay, from the lowest: compound 3; then compounds 2 and 1 (each within the scatter of the next).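

In this assay the place on the carbonyl carbon, whose other neighbour is the amide-type nitrogen, proves not to be indifferent to the group it carries: 3,5-dichlorophenyl in place of thiophen-2-yl gives a number 29 percentage points lower from compound 2 to compound 3 (beyond the scatter) and so breaks the flat picture left by the first pair. The sharper comparison is between the two dichlorophenyl groups, where 3,5-dichlorophenyl in place of 2,6-dichlorophenyl gives a number 37 percentage points lower from compound 1 to compound 3 (beyond the scatter), which shows that the kind of group alone does not set the read-out here, since these two groups differ only in where their chlorines stand. No measurement at hand explains why these two groups part in this way.

The compounds shown leave open whether the drop belongs to the 3,5-dichlorophenyl group alone or would also appear with an unsubstituted phenyl, a single chlorine or a methoxy group on the ring at this place. They also leave open how a group of another kind, such as a piperidine amine or a carboxylic acid, would fare on this carbonyl carbon, and each read-out remains a size at one concentration rather than a potency.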